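A few compounds are considered here, and "the series" means these few. Any claim that something is new, unique, unknown or untested is made for them only; others in the source may bear on it.

Compound 1, `CN(C)CCCNc1nc(-c2ccc(NC(=O)Nc3ccc(F)cc3)cc2)nc2c(Cl)c(Cl)sc12`, gives 980 nM in a functional assay on MDA-MB-231 cells (Homo sapiens) for cytotoxicity, read by MTT assay, with a stated time of 72 h; on this read-out higher numbers stand for weaker inhibition and lower numbers for stronger inhibition. Compound 2, `CN(C)CCCNc1nc(-c2ccc(NC(=O)Nc3ccc(Cl)cc3Cl)cc2)nc2c(Cl)c(Cl)sc12`, gives 3490 nM in this assay. Compound 3, `Cc1ccc(NC(=O)Nc2ccc(-c3nc(NCCCN(C)C)c4sc(Cl)c(Cl)c4n3)cc2)cc1`, gives 4980 nM in this assay.

Among these three, compound 1 stands lowest, which on this read-out means the strongest inhibition. The step to compound 2 is a 3.6-fold higher number from compound 1 to compound 2 (0.55 log units; beyond the scatter), and the step to compound 3 is a 5.1-fold higher number from compound 1 to compound 3 (0.71 log units; beyond the scatter). Between the other two the difference is small: a 1.4-fold higher number from compound 2 to compound 3 (0.15 log units; within the scatter), so compounds 2 and 3 cannot be told apart. All three measured steps change only the aryl group sitting on the urea nitrogen, at the far end of the molecule from the basic side chain.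

Compound 4, `CN(C)CCNc1nc(-c2ccc(NC(=O)Nc3ccc(F)cc3)cc2)nc2c(Cl)c(Cl)sc12`, keeps the 4-fluorophenyl urea of compound 1 and instead alters that side chain: dimethylamino in place of (dimethylamino)methyl on a saturated chain carbon, two bonds along the chain from a nitrogen on an aromatic ring. In plainer words, the chain linking the dimethylamino group to the core is one carbon shorter. Among the compounds with values here, none of the measured steps touches this chain, so they give no direct guide to how this assay will respond; a shortening of this kind is a small change to a flexible part of the molecule, and the expected step is a 1.2-fold higher number from compound 1 to compound 4 (0.09 log units; within the scatter), not clearly beyond the scatter. The estimate for compound 4 is therefore 1200 nM, within a range of 450 nM to 3200 nM.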

Compound 4, half-maximal inhibitory concentration: 1240 nM
Beside the measured number, compound 4's estimate is 1.0-fold (0.01 log units) below it, within the range that was stated.
By their numbers in this assay, from the lowest: compounds 1 and 4 (each within the scatter of the next); then compounds 2 and 3 (each within the scatter of the next).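

The earlier compounds shown here varied only the aryl group on the urea, and there a single swap could carry the number beyond the scatter, as in a 3.6-fold higher number from compound 1 to compound 2 (0.55 log units; beyond the scatter) when 2,4-dichlorophenyl takes the place of 4-fluorophenyl. Compound 4 gives the first view of the side chain: the change from (3-(dimethylamino)propyl)amino to (2-(dimethylamino)ethyl)amino gives a 1.3-fold higher number from compound 1 to compound 4 (0.10 log units; within the scatter) and so leaves the two chain lengths indistinguishable in this assay when the urea carries 4-fluorophenyl. No measurement shown here offers an explanation for this result, which rests on a single pair of compounds.

The compounds shown leave open whether a longer chain, such as 4-(dimethylamino)butyl, would also stay within the scatter of compound 1, and whether a diethylamino group or a hydroxyl group at the end of the chain would be tolerated in place of dimethylamino. They also leave open whether the same change of chain length would give a similar result with a 2,4-dichlorophenyl or 4-methylphenyl group on the urea.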